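Swapping one fluoro for chloro on the difluorophenyl series

The compounds below may be only part of what the source reports. "The series", "measured", "known", "first", "only" and "open" are said of these compounds alone.

compound 1 `O=C(Nc1ccc2[nH]c(=O)oc2c1)C(=O)N1CCN(c2ccc(Cl)cc2)CC1`, 17.8%
compound 2 `O=C(Nc1ccc2[nH]c(=O)oc2c1)C(=O)N1CCN(c2ccc(C(F)(F)F)cc2)CC1`, 24.8%
compound 3 `O=C(Nc1ccc2[nH]c(=O)oc2c1)C(=O)N1CCN(c2ccc(F)c(F)c2)CC1`, 13%

In an ADME assay on the whole organism (Rattus norvegicus, strain Sprague-Dawley) for pharmacokinetics, using cassette dosing, at a dose of 1 mg/kg by the oral route (on this read-out lower numbers stand for lower oral bioavailability and higher numbers for higher oral bioavailability), compound 3 gives 13%. The smaller gap to its two relatives is a number 4.8 percentage points lower from compound 1 to compound 3 (within the scatter), and the larger gap is a number 11.8 percentage points lower from compound 2 to compound 3 (beyond the scatter). Compound 3 therefore cannot be separated from one relative, but it does stand apart from the other.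

The next structure is compound 4 `O=C(Nc1ccc2[nH]c(=O)oc2c1)C(=O)N1CCN(c2ccc(F)c(Cl)c2)CC1`, which has chloro in place of fluoro on an aromatic carbon, ortho to a fluoro group and meta to a large group: chloro in place of fluoro on an aromatic carbon. Among the measured compounds shown here, no measured step makes this exact exchange, so the evidence is indirect. The closest comparison is with compound 1, which also bears a chloro and gives 17.8%. Its step to the difluoro compound is a number 4.8 percentage points lower from compound 1 to compound 3 (within the scatter), and the exchange of chloro for trifluoromethyl is a number 7 percentage points higher from compound 1 to compound 2 (within the scatter). Only the wider replacement of the whole substituted phenyl group in a number 11.8 percentage points lower from compound 2 to compound 3 (beyond the scatter) goes beyond the scatter, and a single-atom exchange is a smaller edit than that. The expected change is slightly upward and is not expected to exceed the scatter, with an estimated a number 4 percentage points higher from compound 3 to compound 4 (within the scatter). For compound 4 the estimated value is 17%, with an expected range from 8% to 28%.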

Compound 4, oral bioavailability: 24.6%
Compound 4: middle estimate off by 7.6 percentage points, on the low side; low and high end bracket the measured number.
By their numbers in this assay, from the lowest: compounds 3, 1, 4 and 2 (each within the scatter of the next, the first and the last beyond it).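

The exchange of fluoro for chloro on an aromatic carbon, ortho to a fluoro group and meta to a large group, is a one-atom edit, yet in this assay it moves the number past the scatter (a number 11.6 percentage points higher from compound 3 to compound 4 (beyond the scatter)). With this chloro in place, the 3-chloro-4-fluorophenyl compound cannot be separated from its 4-(trifluoromethyl)phenyl relative (a number 0.2 percentage points lower from compound 2 to compound 4 (within the scatter)) or from its 4-chlorophenyl relative (a number 6.8 percentage points higher from compound 1 to compound 4 (within the scatter)). A single halogen at this position is therefore enough to separate compound 4 from the difluoro compound, a separation that the 4-chlorophenyl compound does not show (a number 4.8 percentage points lower from compound 1 to compound 3 (within the scatter)).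

From the compounds shown here alone, how a bromo, a methoxy group or a nitrile at this position would read stays open, as does whether the same exchange gives a similar step when the neighbouring fluoro is replaced by another group. Nothing shown here offers a measured reason for the step from the difluoro compound to the chloro-fluoro compound.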